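Swapping the aryl amide for a thiophene: cytotoxicity outlook

The compounds below may be only part of what the source reports. "The series", "measured", "known", "first", "only" and "open" are said of these compounds alone.

Measured compounds:
- compound 1, `O=C(NC(=S)N1CCc2cc(OCc3ccccc3)ccc21)c1ccccc1`: 45200 nM
- compound 2, `O=C(NC(=S)N1CCc2cccc(OCc3ccccc3)c21)c1ccccc1`: > 50000 nM
- compound 3, `O=C(NC(=S)N1CCc2c(OCCCCCOc3ccc(Cl)cc3)cccc21)c1ccc(C(F)(F)F)cc1`: 32700 nM

In an ADME assay on Huh-7 cells (Homo sapiens) for cytotoxicity (on this read-out higher numbers stand for lower toxicity in this test and lower numbers for higher toxicity in this test), compound 3 gives 32700 nM, a number that sits within the usual scatter of the value of compound 1. For compound 2 this assay reports only a limit, (the limit of > 50000 nM in this assay, at which 1 of the 3 values shown sits). Compound 4, `O=C(NC(=S)N1CCc2c(OCCCCCOc3ccc(Cl)cc3)cccc21)c1ccsc1`, has not yet been tested. It differs from compound 3 in one place: thiophen-3-yl in place of 4-(trifluoromethyl)phenyl on a carbonyl carbon. No measured pair shows the effect of such a change, so no cause for any shift can be pointed to. The expectation is a step from compound 3 to compound 4 of a 1.2-fold higher number from compound 3 to compound 4 (0.07 log units; within the scatter), no larger than the scatter. Compound 4 is therefore estimated at 38000 nM, with a range from 18000 nM to 80000 nM.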

Compound 4, half-maximal cytotoxic concentration: > 50000 nM
Compound 4 gave a limit, no number (the forecaster's own chance of this, stated with the estimate: 35%); at least 1.3-fold (0.11 log units) between middle value and limit.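

In this assay, going by these compounds alone, the first measured change at this place, thiophen-3-yl in place of 4-(trifluoromethyl)phenyl on a carbonyl carbon, gives an at least 1.5-fold higher number from compound 3 to compound 4 (0.18 log units; that floor lies within the scatter). Compound 4 reads > 50000 nM, which is a limit of the assay and not a number. The step therefore has only a floor, so this change shows no increase in toxicity, while its true size stays unknown: the limit of > 50000 nM in this assay, at which 2 of the 4 values shown sit.

On these data alone, whether a pyridin-3-yl ring on this carbonyl carbon would read like thiophen-3-yl remains open. So does the effect of a carboxylic acid on the ring there.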